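The source may report more compounds than this note shows. Statements on the series, on what has been measured and on what is new or still open speak of the compounds shown alone.

Compound 2 `COc1cc(-c2nn(-c3cccc(NC(=O)c4ccc(Cl)c(C(F)(F)F)c4)c3)cc2-c2ccncc2)ccc1Cl` is measured in a functional assay on A549 cells (Homo sapiens) for inhibition, read by sulforhodamine B assay, with a stated time of 48 h (a higher number here means a weaker inhibitor of growth, a lower number a stronger inhibitor of growth), at 2400 nM. Among the three measured compounds, compound 2 has the highest number: compound 3 `COc1cc(-c2nn(-c3cccc(NC(=O)c4cccc(C(F)(F)F)c4)c3)cc2-c2ccncc2)ccc1Cl` gives 1870 nM, and compound 1 `O=C(Nc1cccc(-n2cc(-c3ccncc3)c(-c3ccc(Cl)c(O)c3)n2)c1)Nc1ccc(Cl)c(Cl)c1` gives 1010 nM. Among the measured compounds shown here, the one measured step that involves compound 2 is a 1.3-fold lower number from compound 2 to compound 3 (0.11 log units; within the scatter), so the aromatic chloro makes no difference that rises above the scatter. The gap between compound 2 and compound 1 is larger, but the two differ in several places, and nothing more than the two values themselves can be said of that pair.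

Compound 4 `COc1cc(-c2nn(-c3cccc(NC(=O)Nc4ccc(Cl)c(C(F)(F)F)c4)c3)cc2-c2ccncc2)ccc1Cl` is the compound not yet measured. It differs from compound 2 in one place: (4-chloro-3-(trifluoromethyl)phenyl)amino in place of 4-chloro-3-(trifluoromethyl)phenyl on a carbonyl carbon. For the measured compounds named here, no measured pair isolates this change, so the step from compound 2 to compound 4 cannot be read from a matched pair. The nearest guide is compound 1, which also carries an arylamino group on its carbonyl carbon and gives 1010 nM, a number somewhat lower than that of compound 2. On this slender basis, compound 4 is expected to show a 2.0-fold lower number from compound 2 to compound 4 (0.30 log units; within the scatter) in this assay, a modest move toward a lower number. Compound 4 is therefore estimated at 1200 nM, with a range from 400 nM to 3600 nM.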

Compound 4, concentration for 50% growth inhibition: 1020 nM
Beside the measured number, compound 4's estimate is 1.2-fold (0.07 log units) above it; measured number inside the range.
By their numbers in this assay, from the lowest: compounds 1, 4, 3 and 2 (each within the scatter of the next, the first and the last beyond it).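

In this assay, among the compounds shown here, the change on the carbonyl carbon, from 4-chloro-3-(trifluoromethyl)phenyl to (4-chloro-3-(trifluoromethyl)phenyl)amino, gives a 2.4-fold lower number from compound 2 to compound 4 (0.37 log units; beyond the scatter) and is modest, yet it is the first step at this position to rise above the scatter; the loss of the aromatic chloro alone, a 1.3-fold lower number from compound 2 to compound 3 (0.11 log units; within the scatter), did not. The second comparison is less clear: a 1.8-fold lower number from compound 3 to compound 4 (0.26 log units; within the scatter) stays within the scatter, and this step brings in the amino group and the chloro together, so the change is established only against compound 2. No measurement is at hand that would explain the step.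

The compounds shown leave open what the (3-(trifluoromethyl)phenyl)amino group would give on the same carbonyl carbon, a comparison that would separate the amino group from the chloro. They also leave open whether a methylene or a methylamino group in place of the amino group would keep the step seen from compound 2.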